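A few compounds are considered here, and "the series" means these few. Any claim that something is new, unique, unknown or untested is made for them only; others in the source may bear on it.

Measured in an ADME assay on microsomes from liver (Homo sapiens) for metabolic stability, read by LC-MS, using NADPH, with stated times of 5 min and 30 min, tested at 1 uM; a lower number here means slower removal, a higher number faster removal of the compound:

Compound 1 `Cn1cc(-c2cnc(NCc3c(F)ccc4c3CCO4)c3cn[nH]c(=O)c23)cn1`: 21 mL.min-1.g-1
Compound 2 `Cc1ncccc1-c1cnc(NCc2c(F)ccc3c2CCO3)c2nn(CC#N)c(=O)n12`: 151 mL.min-1.g-1
Compound 3 `CN(c1ncco1)c1cnc(NCc2c(F)ccc3c2CCO3)n2cnnc12`: 11 mL.min-1.g-1

Compound 3 and compound 1 together form the low end of these three numbers, and their values lie within the usual scatter of each other. Compound 2 stands apart, beyond that scatter and on the high side of compound 3.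

Compound 4 `Fc1ccc2c(c1CNc1ncc(Oc3ccccc3)c3nncn13)CCO2` has not yet been measured. It carries phenoxy in place of methyl(1,3-oxazol-2-yl)amino on an aromatic carbon of the shared core (phenoxy in place of methyl(1,3-oxazol-2-yl)amino on an aromatic carbon). The group that enters is one six-membered aromatic ring of carbon only, and the group that leaves holds a five-membered aromatic ring with 2 hetero atoms.

For the measured compounds named here, no two measured compounds differ in one place only, so no measured step speaks directly to this exchange. The data show only how wide the numbers can run, with compound 2 at 151 mL.min-1.g-1 marking the high side. A moderate upward step is therefore expected, somewhat beyond the scatter, though this is a judgement with little support. The estimate corresponds to an expected rise a 3.2-fold higher number from compound 3 to compound 4 (0.50 log units; beyond the scatter). For compound 4 the estimated value in this assay is 35 mL.min-1.g-1, with an expected range from 12 mL.min-1.g-1 to 100 mL.min-1.g-1.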

Compound 4, intrinsic clearance in microsomes: 18 mL.min-1.g-1
Compound 4: the middle estimate sits 1.9-fold (0.29 log units) above what was measured, and the stated range covers the measured number.
By their numbers in this assay, from the lowest: compounds 3, 4 and 1 (each within the scatter of the next); then compound 2.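

In this assay, for the compounds shown here, the exchange of methyl(1,3-oxazol-2-yl)amino for phenoxy on an aromatic carbon of the shared core gives the only step that can be read at this position (a 1.6-fold higher number from compound 3 to compound 4 (0.21 log units; within the scatter)). Going by these compounds alone, at this place, then, a group with one six-membered aromatic ring of carbon only and 1 hydrogen-bond acceptor cannot be told apart in this read-out from a group with one five-membered aromatic ring with 2 hetero atoms and 3 hydrogen-bond acceptors, at the same 7 heavy atoms, so the earlier compounds' wide spread of numbers finds no counterpart in this single exchange. Nothing measured on these compounds bears on why the two groups read alike.

The compounds shown leave open whether this tolerance holds for other kinds of group at this aromatic carbon, such as a primary amine, a carboxylic acid, a morpholine or a longer chain like benzyloxy, or for a phenoxy carrying a substituent such as chlorine or methoxy on its ring. They also leave open whether the same exchange would read alike on the cores of compound 1 and compound 2, which differ from compound 3 in more than one place.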